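The source may report more compounds than this note shows. Statements on the series, on what has been measured and on what is new or still open speak of the compounds shown alone.

Compound 1 `CS(=O)(=O)CCCn1c(Cn2c(=O)n(C3CC3)c3ccncc32)cc2cc(Cl)ccc21` is tested in an ADME assay on HeLa cells (Homo sapiens) for cytotoxicity, read by ATP content, with a stated time of 3 days (a lower number here means that less compound is tolerated, a higher number that more compound is tolerated), where compound 1 gives > 50000 nM, which is a limit of the assay rather than a number. Compound 2 `O=c1n(Cc2cc3cc(Cl)ccc3n2CCCCO)c2cnccc2n1C1CC1` also gives only a limit in this assay, > 50000 nM. The change between them is therefore a step that the two limits leave unreadable from compound 1 to compound 2. Compound 3 `CC(C)n1c(=O)n(Cc2cc3cc(Cl)ccc3n2CCCS(C)(=O)=O)c2cnccc21` differs from compound 1 by isopropyl in place of cyclopropyl on an aromatic nitrogen. Within the data shown here, no measured step covers this change. Because (the limit of > 50000 nM in this assay, at which 2 of the 2 values shown sit), no step beyond the scatter is expected in this assay for compound 3. Compound 3 is therefore estimated at 50000 nM, with a range from 25000 nM to 100000 nM. The expected step is a number no higher from compound 1 to compound 3 (the limit leaves the size open).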

Compound 3, half-maximal cytotoxic concentration: > 50000 nM
Compound 3 was reported as a limit (the forecaster's own chance of this, stated with the estimate: 85%); the middle value lies on the limit itself.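

Compound 1 and compound 3 each give only a limit, so no step can be read between them: the limit of > 50000 nM in this assay, at which 3 of the 3 values shown sit.

Whether isopropyl in place of cyclopropyl changes how much compound the cells tolerate remains open, as does how much of any of these compounds they tolerate.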